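The compounds below may be only part of what the source reports. "The series", "measured", "known", "first", "only" and "open" are said of these compounds alone.

Working notes on the chalcone series. Three compounds have numbers in an assay on A549 cells for inhibition of transcription factor p65 (Homo sapiens), read by fluorescence, with a stated time of 2 h (a higher number here means a weaker inhibitor, a lower number a stronger inhibitor), so far. Compound 1, `COc1ccc(/C=C/C(=O)c2ccc(N)c(-c3ccc(F)cc3)c2)cc1`, gives only a limit in this assay: > 50000 nM, a limit of the assay rather than a number, as the limit of > 50000 nM in this assay, at which 1 of the 3 values shown sits, records. Compound 2, `O=C(/C=C/c1cccc(Br)c1)c1cccc(-c2cccc(F)c2)c1`, gives 11200 nM in this assay. Compound 3, `COc1ccc(/C=C/C(=O)c2cccc(-c3cccc(F)c3)c2)cc1OC`, gives 33400 nM in this assay. Of the two numbers shown, compound 2 stands lowest, and compound 3 gives the higher number, a gap that is beyond the scatter; no single-place step connects the two, so nothing more is read from the pair.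

Compound 4, `O=C(/C=C/c1ccc(Cl)cc1)c1cccc(-c2cccc(F)c2)c1`, is not yet measured. Against compound 2 the change is 4-chlorophenyl in place of 3-bromophenyl on a double-bonded chain carbon bound to a double-bonded chain carbon; the rest of the structure is kept. Among the measured compounds shown here, no step between measured compounds resembles this swap, so no measured guide exists for it. The expectation is that the step from compound 2 to compound 4 stays within the scatter, or at most a small shift in either direction, and the estimated step is a 1.1-fold higher number from compound 2 to compound 4 (0.03 log units; within the scatter). For compound 4 in this assay the estimate is 12000 nM, with a range from 5000 nM to 32000 nM; a limit instead of a number is held possible but unlikely.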

Compound 4, half-maximal inhibitory concentration: 24400 nM
Compound 4: middle estimate off by 2.0-fold (0.31 log units), on the low side; the range from low to high includes it.
By their numbers in this assay, from the lowest: compound 2; then compounds 4 and 3 (each within the scatter of the next). At a limit, above all of these: compound 1.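

In this assay, among the compounds shown here, the series now has its only single-place step: a 2.2-fold higher number from compound 2 to compound 4 (0.34 log units; beyond the scatter), with 4-chlorophenyl in place of 3-bromophenyl on a double-bonded chain carbon bound to a double-bonded chain carbon. The step is modest, but it shows that the number at this place responds to a swap that leaves the heavy-atom count, the ring and the donor and acceptor counts as they were, though the halogen and the position printed in the group's name change together. No measurement shown accounts for this step.

The compounds shown leave open whether the halogen or its position carries the step, a question that 3-chlorophenyl or 4-bromophenyl at this place would separate. Also open, from the compounds shown here alone, is how a group of another kind at this place, such as an amine or a carboxylic acid on the phenyl ring, would read in this assay.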